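The source may hold more compounds than are shown below. What is called first, only, known or untested is meant among the compounds shown, and "the series" means these compounds.

Of the compounds shown here, three built on a shared core have been tested in a functional assay on A375P cells (Homo sapiens) for inhibition, read by MTT assay, with a stated time of 24 h; a lower number here means a stronger inhibitor of growth, a higher number a weaker inhibitor of growth. In it, compound 1 `O=C1CC(c2cccc(NC(=O)c3ccc(Cl)c(C(F)(F)F)c3)c2)=Nc2cnn(Cc3ccccc3)c2N1` gives 430 nM, and compound 2 `O=C1CC(c2ccc(NC(=O)c3ccc(Cl)c(C(F)(F)F)c3)cc2)=Nc2cnn(Cc3ccccc3)c2N1` gives 13100 nM. Compound 3 `Cc1cn(-c2cc(C(=O)Nc3ccc(C4=Nc5cnn(Cc6ccccc6)c5NC(=O)C4)cc3)cc(C(F)(F)F)c2)cn1` reads > 30000 nM, which is a limit of the assay and not a number. Of the two real numbers, compound 2 holds the higher one. That makes it the weaker growth inhibitor of the pair, and its gap to compound 1 lies well beyond the scatter of repeated measurements.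

The next compound, compound 4 `O=C1CC(c2ccc(NC(=O)Nc3cccc(Cl)c3)cc2)=Nc2cnn(Cc3ccccc3)c2N1`, has not yet been measured. It departs from compound 2 in one place, on a carbonyl carbon whose other neighbours are an amide-type nitrogen: (3-chlorophenyl)amino stands in place of 4-chloro-3-(trifluoromethyl)phenyl ((3-chlorophenyl)amino in place of 4-chloro-3-(trifluoromethyl)phenyl on a carbonyl carbon). Among the measured compounds shown here, no pair of tested compounds shows what such a swap does. The expectation in this assay is therefore for no change beyond the scatter in either direction, starting from compound 2 at 13100 nM. The estimated step of a 1.3-fold lower number from compound 2 to compound 4 (0.12 log units; within the scatter) is accordingly small. For compound 4 the estimated value is 10000 nM, with an expected range from 3000 nM to 30000 nM.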

Compound 4, concentration for 50% growth inhibition: 2070 nM
Beside the measured number, compound 4's estimate is 4.8-fold (0.68 log units) above it; measured number below the stated range.
By their numbers in this assay, from the lowest: compound 1; then compound 4; then compound 2. At a limit, above all of these: compound 3.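

In this assay, putting (3-chlorophenyl)amino in place of 4-chloro-3-(trifluoromethyl)phenyl on a carbonyl carbon gives a 6.3-fold lower number from compound 2 to compound 4 (0.80 log units; beyond the scatter). Among the compounds shown here, this is the first measured step at this place, and it shows that the number in this assay responds to what is attached to that carbonyl carbon. The change is not a single one, though: the entering group has fewer heavy atoms than the group that leaves, it brings a nitrogen with 1 hydrogen-bond donor where the leaving group has 0, and the trifluoromethyl is lost while the chlorine stays on the ring.

With these changes made together in one step, the compounds shown leave open which of them accounts for the lower number, and whether a smaller group such as methyl or a saturated ring such as cyclohexyl on that same nitrogen would behave like the 3-chlorophenyl. Compound 3 reads only a limit of the assay and not a number, so it puts no size on any step: the limit of > 30000 nM in this assay, at which 1 of the 4 values shown sits.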